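A few compounds are considered here, and "the series" means these few. Any claim that something is new, unique, unknown or untested is made for them only; others in the source may bear on it.

Compound 1 `O=C(Nc1cccc(F)c1)c1cncc(N2CC3CC(C2)N3)c1` is the anchor of this set. In an assay on cells for displacement of a labelled ligand from Neuronal acetylcholine receptor; alpha3/beta4 (Homo sapiens) (a lower number here means a stronger inhibitor, a higher number a weaker inhibitor), compound 1 gives 28 nM, the lowest of the three numbers measured. Compound 2 `O=C(c1cncc(N2CC3CC(C2)N3)c1)N1CCCc2ccccc21` gives 62 nM in this assay, and compound 3 `COc1ccc(NC(=O)c2cncc(N3CC4CC(C3)N4)c2)cc1OC` gives 516 nM; both lie above compound 1 by more than the usual scatter, compound 3 by far the most.

Compound 4 `O=C(Nc1ccc(F)cc1)c1cncc(N2CC3CC(C2)N3)c1` is not yet measured. It differs from compound 1 in one place only: 4-fluorophenyl in place of 3-fluorophenyl on an amide-type nitrogen. Among the compounds with values here, no measured pair shows this kind of change, so its effect is uncertain; a modest step is expected, if any, likely within or just beyond the scatter and slightly toward a higher number. The expected step is a 1.4-fold higher number from compound 1 to compound 4 (0.15 log units; within the scatter). Compound 4 is estimated at 40 nM, with a range from 15 nM to 110 nM.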

Compound 4, inhibition constant: 81 nM
Beside the measured number, compound 4's estimate is 2.0-fold (0.31 log units) below it; low and high end bracket the measured number.
By their numbers in this assay, from the lowest: compound 1; then compounds 2 and 4 (each within the scatter of the next); then compound 3.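

In this assay, 4-fluorophenyl in place of 3-fluorophenyl on the amide-type nitrogen gives a 2.9-fold higher number from compound 1 to compound 4 (0.46 log units; beyond the scatter). Within the data shown here, this is the first measured pair in the set, and it shows that at this position the number responds to where the fluorine sits on the ring, even with the same atoms present. Nothing measured here gives a reason for the step. Still open, going by these compounds, is whether fluorine itself matters: how plain phenyl or 3-chlorophenyl would stand against compound 1 cannot be told from these compounds.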